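The compounds below may be only part of what the source reports. "The series", "measured", "known", "first", "only" and "open" are said of these compounds alone.

Measured in a functional assay on cardiac atrium (Cavia porcellus); on this read-out higher numbers stand for an effect only at larger amounts of compound and lower numbers for an effect already at smaller amounts:
compound 1 `COC(=O)C1=C(C)NC(C)=C(C(=O)OC)C1c1c(-c2cccs2)nc2sccn12`: 1300 nM
compound 2 `COC(=O)C1=C(C)NC(C)=C(C(=O)OC)C1c1c(-c2ccccn2)nc2sc(C)cn12`: 39900 nM
compound 3 `COC(=O)C1=C(C)NC(C)=C(C(=O)OC)C1c1c(-c2ccncc2)nc2sc(C)cn12`: 7490 nM

Of the three numbers, compound 3 at 7490 nM is the second highest. Compound 2 lies above it and compound 1 below it, both gaps beyond the scatter.

Next in line is the unmeasured compound 4 `COC(=O)C1=C(C)NC(C)=C(C(=O)OC)C1c1c(-c2cccs2)nc2sc(C)cn12`. The change is thiophen-2-yl in place of pyridin-4-yl on an aromatic carbon.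

Within the data shown here, only one measured step bears directly on this place: a 5.3-fold lower number from compound 2 to compound 3 (0.73 log units; beyond the scatter), a modest step with pyridin-4-yl in place of pyridin-2-yl. Among the measured compounds shown here, no measured step covers thiophen-2-yl directly. For the measured compounds named here, compound 1 carries that group, but on a core that differs from that of compound 4 by a methyl group, and compound 1 shows 1300 nM, the lowest number so far. A modest step towards a lower number is therefore expected in this assay. The expected move is a 3.4-fold lower number from compound 3 to compound 4 (0.53 log units; beyond the scatter). For compound 4 the estimated value is 2200 nM, with an expected range of 700 nM to 7000 nM.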

Compound 4, half-maximal effective concentration: 40500 nM
The estimate for compound 4 lay 18-fold (1.27 log units) below the measured number, and the stated range ends below it.
By their numbers in this assay, from the lowest: compound 1; then compound 3; then compounds 2 and 4 (each within the scatter of the next).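

In this assay, thiophen-2-yl in place of pyridin-4-yl gives a 5.4-fold higher number from compound 3 to compound 4 (0.73 log units; beyond the scatter), and thiophen-2-yl in place of pyridin-2-yl gives a 1.0-fold higher number from compound 2 to compound 4 (0.01 log units; within the scatter), so among the methyl-bearing compounds only the pyridin-4-yl group stands apart, while thiophen-2-yl and pyridin-2-yl cannot be told apart. Methyl in place of hydrogen on an aromatic carbon gives a 31-fold higher number from compound 1 to compound 4 (1.49 log units; beyond the scatter), the largest step in the series so far and larger than either exchange of the aromatic group. The data on hand offer no explanation for either result.

Among these compounds, whether the methyl step is of similar size with pyridin-4-yl or pyridin-2-yl remains open, since thiophen-2-yl provides the only such pair. Also open, as far as these compounds go, is how an ethyl group or an amine in place of that methyl, or a phenyl ring in place of thiophen-2-yl, would read out.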